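Swapping the Aryl Group on the Triazole Nitrogen

A few compounds are considered here, and "the series" means these few. Any claim that something is new, unique, unknown or untested is made for them only; others in the source may bear on it.

Compound 1 `COc1ccc([C@@H]2C/C(=N/OCc3cn(-c4ccc(Cl)cc4C)nn3)c3cc(CC=C(C)C)c(OC)cc3O2)cc1`: 20%
Compound 2 `COc1ccc([C@@H]2C/C(=N/OCc3cn(-c4cc(OC)c(OC)c(OC)c4)nn3)c3cc(CC=C(C)C)c(OC)cc3O2)cc1`: 29%

Both compounds were tested in a functional assay on HCT-116 cells (Homo sapiens) for inhibition, read by sulforhodamine B assay, with a stated time of 48 h, tested at 50 uM (a higher number here means more inhibition of growth at the concentration tested, a lower number less inhibition of growth), and they share a core, differing only in the group on an aromatic nitrogen. In this assay, going by the values given here, compound 2 gives 29%, which stands within the scatter of compound 1, the only other measured compound. Among the compounds with values here, the single measured step is a number 9 percentage points higher from compound 1 to compound 2 (within the scatter), with 3,4,5-trimethoxyphenyl in place of 4-chloro-2-methylphenyl.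

Compound 3 `COc1ccc([C@@H]2C/C(=N/OCc3cn(-c4ccc(C(N)=O)cc4)nn3)c3cc(CC=C(C)C)c(OC)cc3O2)cc1` changes the same place, with 4-carbamoylphenyl in place of 3,4,5-trimethoxyphenyl on an aromatic nitrogen of the five-membered aromatic ring with 3 nitrogen: 4-carbamoylphenyl in place of 3,4,5-trimethoxyphenyl on an aromatic nitrogen. Within the data shown here, no measured compound carries 4-carbamoylphenyl, and one step is thin evidence. Among the measured compounds shown here, still, the one exchange at this place, a number 9 percentage points higher from compound 1 to compound 2 (within the scatter), did not move the number beyond the scatter. No step beyond the scatter is therefore expected, and no direction can be argued with confidence. The estimate amounts to a number 4 percentage points lower from compound 2 to compound 3 (within the scatter), which is an expected step and not a measured one. For compound 3 the estimated value is 25%, with an expected range from 10% to 42%.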

Compound 3, percent growth inhibition at one concentration: 100%
Compound 3: middle estimate off by 75 percentage points, on the low side; measured number outside the range, above it.
By their numbers in this assay, from the lowest: compounds 1 and 2 (each within the scatter of the next); then compound 3.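

In this assay, the group on the aromatic nitrogen proves able to move the number strongly: 4-carbamoylphenyl gives a number 71 percentage points higher from compound 2 to compound 3 (beyond the scatter), and against the other aryl group it gives a number 80 percentage points higher from compound 1 to compound 3 (beyond the scatter), whereas the earlier exchange at this place stayed within the scatter. The position therefore does not tolerate every aryl exchange equally, and the number depends on which group enters, a point that compounds 1 and 2 alone could not show. Compared with 3,4,5-trimethoxyphenyl, the entering 4-carbamoylphenyl has 1 hydrogen-bond donor instead of 0 and 1 double bond outside aromatic rings, but no measurement here connects either difference to the result.

The compounds shown do not separate the carbamoyl group from the phenyl ring that carries it, so it remains open whether a carboxylic acid, a nitrile or a sulfonamide in its place would give a comparable number. Also open, as far as these compounds go, is whether a benzyl group, with one carbon between the triazole nitrogen and the ring bearing the carbamoyl group, would keep the number of compound 3.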